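Removing the aromatic methyl from compound 1

The source may hold more compounds than are shown below. What is called first, only, known or untested is meant among the compounds shown, and "the series" means these compounds.

In a functional assay on MDA-MB-231 cells (Homo sapiens) for antiproliferative activity, read by MTT assay (on this read-out lower numbers stand for stronger inhibition and higher numbers for weaker inhibition), compound 1 (`CCCCC/C=C\C/C=C\CCCCCCCc1cc(=O)c2c(O)c(C)c(OCOC)cc2o1`) reads > 87000 nM as a limit of the assay and not a number. Compound 2 (`CC/C=C\C/C=C\C/C=C\CCCCCCCc1cc(=O)c2c(O)c(C)c(OCOC)cc2o1`) gives 6790 nM in this assay as a measured value. Within the data shown here, the only measured step is an at least 12-fold lower number from compound 1 to compound 2 (1.10 log units; beyond the scatter) and it lies in the chain, with but-1-en-1-yl in place of butyl on a saturated chain carbon bound to a double-bonded chain carbon. Compound 3 (`CCCCC/C=C\C/C=C\CCCCCCCc1cc(=O)c2c(O)cc(OCOC)cc2o1`) keeps the chain of compound 1 and instead carries hydrogen in place of methyl on an aromatic carbon. Among the measured compounds shown here, no measured step covers that change, so the chain step gives it no size. No step beyond the scatter is expected in this assay and no direction is favoured, which puts the expected shift at a step that the limit leaves unreadable from compound 1 to compound 3 for now. Compound 3 is estimated at 90000 nM within a range of 30000 nM to 200000 nM. Once tested, it may well give only a limit of the assay.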

Compound 3, half-maximal inhibitory concentration: > 87000 nM
Compound 3 was reported as a limit (the forecaster's own chance of this, stated with the estimate: 60%); the middle value lies beyond the limit too.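

In this assay no step can be read between compound 1 and compound 3, as each stands at a limit of the assay: the limit of > 87000 nM in this assay, at which 2 of the 3 values shown sit. On these data alone, whether hydrogen in place of methyl on an aromatic carbon changes the read-out at all stays open, as does its size on the chain of compound 2.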